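Replacing the Amide Side Chain with a Dicarboxyethyl Group

This account rests on a few compounds, and the source may have more. Where it says the series, first, only, none or still open, it means among the compounds named here.

Three compounds have been measured in a functional assay on MCF7 cells (Homo sapiens) for antiproliferative activity, read by MTT assay, with a stated time of 24 h; a higher number here means a weaker inhibitor, a lower number a stronger inhibitor:

Compound 1, `CCn1c(C(=O)N[C@@H](C)C(=O)OC)ccc1C(CC)(CC)c1ccc(OCS(=O)(=O)c2ccccc2)c(C)c1`, gives 43700 nM.
Compound 2, `CCn1c(C(=O)N[C@H](CO)C(C)C)ccc1C(CC)(CC)c1ccc(OCS(=O)(=O)c2ccccc2)c(C)c1`, gives 25500 nM.
Compound 3, `CCn1c(C(=O)N[C@H](C)C(=O)O)ccc1C(CC)(CC)c1ccc(OCS(=O)(=O)c2ccccc2)c(C)c1`, reaches only the assay limit of > 50000 nM.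

Compound 2 stands at the lowest of the two numbers, with compound 1 nearest to it; the step of a 1.7-fold lower number from compound 1 to compound 2 (0.23 log units; within the scatter) lies within the scatter. Compound 3 is known only as a limit.

Compound 4, `CCn1c(C(=O)N[C@H](CC(=O)O)C(=O)O)ccc1C(CC)(CC)c1ccc(OCS(=O)(=O)c2ccccc2)c(C)c1`, has not been measured. It differs from compound 2 as 1,2-dicarboxyethyl in place of 1-(hydroxymethyl)-2-methylpropyl on an amide-type nitrogen.

Among the measured compounds shown here, two measured steps bear on this change, since both introduce a carboxyl on the same amide-type nitrogen: an at least 1.9-fold higher number from compound 2 to compound 3 (0.29 log units; that floor lies within the scatter) and an at least 1.1-fold higher number from compound 1 to compound 3 (0.05 log units; that floor lies within the scatter). In each case the carboxylic acid lands at the floor of the assay, (the limit of > 50000 nM in this assay, at which 1 of the 3 values shown sits), so neither step can be sized beyond that floor. Compound 4 carries two carboxyls where compound 3 carries one. For the measured compounds named here, compound 2 is the only compound whose step to compound 4 is of interest here, and the acid compound 3 gives the only guide.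

Compound 4 is therefore expected to show a higher number than compound 2, most probably at the assay limit, with an estimate of 65000 nM between 30000 nM and 140000 nM. For compound 4 this means an expected 2.5-fold higher number from compound 2 to compound 4 (0.41 log units; beyond the scatter).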

Compound 4, half-maximal inhibitory concentration: > 50000 nM
Compound 4: only a limit was reported (the forecaster's own chance of this, stated with the estimate: 65%); the middle value lies beyond the limit too.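

Compound 4, which carries 1,2-dicarboxyethyl on the amide-type nitrogen, is the second carboxylic acid in this assay to end at a limit rather than a number: the limit of > 50000 nM in this assay, at which 2 of the 4 values shown sit.

Against the 1-(hydroxymethyl)-2-methylpropyl side chain the result is an at least 1.9-fold higher number from compound 2 to compound 4 (0.29 log units; that floor lies within the scatter), and against the 1-(methoxycarbonyl)ethyl side chain it is an at least 1.1-fold higher number from compound 1 to compound 4 (0.05 log units; that floor lies within the scatter), so neither floor shows a separation beyond the scatter. The step between the two acids, compound 3 and compound 4, cannot be read, so the extra carboxy on the saturated chain carbon has no measurable size here, and among the four compounds only the two without a free carboxylic acid, compound 1 and compound 2, give actual numbers.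

From the compounds shown here alone, how far past the limit the two acids lie stays open, and with it whether the second carboxyl changes anything at all. Also open, going by these compounds, is how this position would read with a primary amine, a primary carboxamide or a longer chain ending in a carboxylic acid on the amide-type nitrogen.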